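A few compounds are considered here, and "the series" means these few. Any claim that something is new, unique, unknown or untested is made for them only; others in the source may bear on it.

Compound 2 `N#CC1=C(N)N(c2ccc(S(N)(=O)=O)cc2)C2=C(C(=O)CCC2)C1/C=C/c1ccccc1` carries a 2-phenylethenyl group on a saturated ring carbon of the shared core. In a functional assay on Ehrlich cells (Mus musculus) for antiproliferative activity, read by trypan blue exclusion, with a stated time of 2 h, tested at 50 ug/mL (a lower number here means a weaker effect, a higher number a stronger effect of the compound at the concentration tested), compound 2 gives 40%. Compound 1 `N#CC1=C(N)N(c2ccc(S(N)(=O)=O)cc2)C2=C(C(=O)CCC2)C1c1ccccc1` carries a phenyl group at that carbon and in this assay compound 1 gives 40%; the step of no change at the digits printed from compound 1 to compound 2 (within the scatter) shows that these two stand level at the digits reported, together the highest of the three numbers. Compound 3 `COc1ccccc1C1C(C#N)=C(N)N(c2ccc(S(N)(=O)=O)cc2)C2=C1C(=O)CCC2` carries a 2-methoxyphenyl group there and in this assay compound 3 gives 0%; the step of a number 40 percentage points lower from compound 2 to compound 3 (beyond the scatter) is large, and so is a number 40 percentage points lower from compound 1 to compound 3 (beyond the scatter).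

Compound 4 `COc1cc(CC2C(C#N)=C(N)N(c3ccc(S(N)(=O)=O)cc3)C3=C2C(=O)CCC3)ccc1O` differs from compound 2 at the same saturated ring carbon: 4-hydroxy-3-methoxybenzyl in place of 2-phenylethenyl on a saturated ring carbon

Going by the values given here, two measured steps bear on this change, both at that carbon. One, from phenyl to 2-phenylethenyl, left the number unchanged within the scatter; the other, to 2-methoxyphenyl, wiped the activity out. The group entering compound 4 again bears a methoxy on its aromatic ring, though set on a benzyl rather than directly on the core, so the expectation leans toward a loss, with wide uncertainty. Compound 4 is therefore expected to give 20%, in a range from 0% to 45%, which would mean an estimated step of a number 20 percentage points lower from compound 2 to compound 4 (beyond the scatter).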

Compound 4, a percentage reported as activity, at one concentration (the size of the read-out at that concentration, not a potency): 90%
Estimate against measurement, compound 4: 70 percentage points below, and the stated range ends below it.
By their numbers in this assay, from the lowest: compound 3; then compounds 1 and 2 (each within the scatter of the next); then compound 4.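

In this assay, going by these compounds alone, the saturated ring carbon proves able to carry a far stronger effect than the earlier compounds showed: 4-hydroxy-3-methoxybenzyl gives a number 50 percentage points higher from compound 2 to compound 4 (beyond the scatter) and a number 50 percentage points higher from compound 1 to compound 4 (beyond the scatter) so the shared level of those two compounds was no ceiling for this position. A methoxy on the aromatic ring of the entering group also does not go with loss in every compound shown, for the two methoxy-bearing compounds lie at opposite ends of the series, with a number 90 percentage points higher from compound 3 to compound 4 (beyond the scatter) and compound 3 following that pattern while compound 4 goes against it. No measurement at hand gives a reason for this rise.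

As far as these compounds go, whether the hydroxy, the methoxy or the benzyl carbon carries the rise remains open, as compound 4 brings all three in together. The compounds shown also do not tell how an amine or a carboxylic acid in place of that hydroxy would read, and a result at one concentration gives the size of the effect, not a potency.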